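From compound 1 to compound 3: a pyrimidinyl swap

The source may hold more compounds than are shown below. What is called first, only, known or untested is meant among the compounds shown, and "the series" means these compounds.

Measured in a functional assay on K562 cells (Homo sapiens) for antiproliferative activity, read by sulforhodamine B assay, with a stated time of 72 h; a lower number here means a stronger inhibitor, a higher number a weaker inhibitor:
- compound 1 `Cc1cc(C)nc(NS(=O)(=O)c2ccc(Nc3nncc4ccccc34)cc2)n1`: 4.9 nM
- compound 2 `C(=C/c1ccccc1)\C(=N\Nc1nncc2ccccc12)c1ccccc1`: 4.4 nM

Compound 1, at 4.9 nM, stands level with compound 2, at 4.4 nM, as the two values lie within the scatter of each other. Compound 3 `O=S(=O)(Nc1ncccn1)c1ccc(Nc2nncc3ccccc23)cc1` has yet to be measured in this assay. It carries pyrimidin-2-yl in place of 4,6-dimethylpyrimidin-2-yl on a sulfonamide nitrogen. Going by the values given here, no measured pair isolates this change or any other single change, so the expectation is anchored only on compound 1 at 4.9 nM and carries a wide margin. The expected 1.2-fold higher number from compound 1 to compound 3 (0.09 log units; within the scatter) is a small one that stays within the scatter, with no clear direction. Compound 3 is estimated at 6 nM, with an expected range of 2 nM to 20 nM.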

Compound 3, half-maximal inhibitory concentration: 43 nM
Beside the measured number, compound 3's estimate is 7.2-fold (0.86 log units) below it; the measured number lies above the stated range.
By their numbers in this assay, from the lowest: compounds 2 and 1 (each within the scatter of the next); then compound 3.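

In this assay, going by these compounds alone, pyrimidin-2-yl in place of 4,6-dimethylpyrimidin-2-yl on a sulfonamide nitrogen gives an 8.8-fold higher number from compound 1 to compound 3 (0.94 log units; beyond the scatter), the first readable single change. This position is therefore sensitive to the change, and the 4,6-dimethylpyrimidin-2-yl group of compound 1 gives the stronger inhibitor of the pair. The two groups have the same ring description and the same hydrogen-bond donor and acceptor counts, but nothing on hand explains the step.

A single pair cannot show whether both methyl groups are needed, so a 4-methylpyrimidin-2-yl group would be informative here. On these data alone, it also remains open whether a 4,6-dimethoxypyrimidin-2-yl group or a plain phenyl ring on the sulfonamide nitrogen would keep the level of compound 1.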